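Series notes: propyl shortened to ethyl, on two cores

The compounds below may be only part of what the source reports. "The series", "measured", "known", "first", "only" and "open" are said of these compounds alone.

Measured in an assay on isolated protein for binding affinity to corticotropin-releasing factor receptor 1 (Homo sapiens); a lower number here means a stronger inhibitor, a higher number a weaker inhibitor:
compound 1 `CCCN(Cc1ccccc1)c1nc(C)nc(Nc2c(C)cc(C)cc2C)n1` — 490 nM
compound 2 `CCN(Cc1ccccc1)c1nc(C)nc(Nc2c(C)cc(C)cc2C)n1` — 1470 nM
compound 3 `CCCN(Cc1ccccc1)c1nc(C)nc(Nc2c(CC)cccc2CC)n1` — reported only as a limit, > 10000 nM

Compound 1 and compound 2 share a core and differ in one place, (hydrogen in place of methyl on a saturated chain carbon, two bonds along the chain from a nitrogen on an aromatic ring). This change gave a 3.0-fold higher number from compound 1 to compound 2 (0.48 log units; beyond the scatter), a weakening in binding that is beyond the usual scatter. Compound 3 carries a different core; the difference between the core of compound 1 and the core of compound 3 is not broken down here. For compound 3 the value in this assay is a limit, (the limit of > 10000 nM in this assay, at which 1 of the 3 values shown sits), not a number.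

Compound 4 `CCc1cccc(CC)c1Nc1nc(C)nc(N(CC)Cc2ccccc2)n1` has not been measured. It differs from compound 3 by hydrogen in place of methyl on a saturated chain carbon, two bonds along the chain from a nitrogen on an aromatic ring, the same change that separates compound 1 and compound 2. On the core of compound 1 the change gave a 3.0-fold higher number from compound 1 to compound 2 (0.48 log units; beyond the scatter), so on the core of compound 3 a step of similar sign and size is expected, a step that the limit leaves unreadable from compound 3 to compound 4. Because compound 3 already sits at the limit of > 10000 nM in this assay, at which 1 of the 3 values shown sits, a weakening of this size is expected to leave compound 4 beyond the limit as well, so that this assay most likely reports only a limit for it. As a working figure, compound 4 is estimated at 30000 nM, within 10000 nM to 100000 nM, with the number itself unlikely to be resolved.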

Compound 4, inhibition constant: 1700 nM
Beside the measured number, compound 4's estimate is 18-fold (1.25 log units) above it; measured number outside the range, below it.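

In this assay the change from propyl to ethyl gave an at least 5.8-fold lower number from compound 3 to compound 4 (0.76 log units; beyond the scatter) and so strengthened binding on the core of compound 3, where the same change on the core of compound 1 had weakened it. On these two cores the change therefore does not carry over, even in direction, and a step read on one core gave no usable guide to the step on the other: the same change on two cores in this assay, a 3.0-fold higher number (0.48 log units; beyond the scatter) from compound 1 to compound 2 and an at least 5.8-fold lower number (0.76 log units; beyond the scatter) from compound 3 to compound 4, at least 17-fold (1.24 log units) apart, beyond the scatter of two such steps.
Compound 3 is reported only as a limit, so the true size of its step stays unknown, and two pairs give neither a rule for other cores in the series nor a reason for the reversal: the limit of > 10000 nM in this assay, at which 1 of the 4 values shown sits.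

Still open is which part of the difference between the core of compound 1 and the core of compound 3 turns the step around, as no compound shown separates those parts. A longer chain such as butyl, or a shorter one such as methyl, on both cores would show whether the two cores keep opposite trends along the chain or whether the reversal is confined to propyl and ethyl.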